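A few compounds are considered here, and "the series" means these few. Any claim that something is new, unique, unknown or untested is made for them only; others in the source may bear on it.

Measured compounds:
compound 1 `Cc1cc(NC(=O)Nc2cccc(C(N)=O)c2)c2ccccc2n1`, > 25000 nM
compound 2 `Cc1cc(NC(=O)Nc2ccccc2C(N)=O)c2ccccc2n1`, > 25000 nM
compound 3 `Cc1cc(NC(=O)Nc2cnc3ccccc3c2)c2ccccc2n1`, > 25000 nM

Of the compounds shown here, three built on one shared core have been tested in an ADME assay on HEK293 cells (Homo sapiens) for cytotoxicity, with a stated time of 72 h; a lower number here means that less compound is needed, a higher number that more compound is needed for the effect. For compound 1 the result is a limit of the assay and not a number, > 25000 nM. Compound 2 likewise returns only a limit, > 25000 nM. Compound 3 also returns only a limit, > 25000 nM. Compound 1 therefore stands together with the other two at the limit of > 25000 nM in this assay, at which 3 of the 3 values shown sit, and nothing on these numbers separates any of them. For the measured compounds named here, no two measured compounds differ in just one place, so no measured step is available to read a size of change from.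

Compound 4 `Cc1cc(NC(=O)Nc2cccc(F)c2)c2ccccc2n1` has not yet been tested. It differs from compound 1 in one place: fluoro in place of carbamoyl on an aromatic carbon. With every measured value sitting at the same limit, the expectation for this change in this assay is a step of none beyond the usual scatter. Compound 4 is therefore expected to give about 40000 nM in this assay, within 15000 nM to 100000 nM, most likely again reported only as a limit. That estimate means an expected step that the limit leaves unreadable from compound 1 to compound 4.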

Compound 4, half-maximal effective concentration: > 25000 nM
Compound 4 was reported as a limit; the forecaster's own chance of this, stated with the estimate: 85%; the middle value does not contradict the limit.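

Compound 1 and compound 4 both return a limit of this assay and not a number, so no step between them can be read: the limit of > 25000 nM in this assay, at which 4 of the 4 values shown sit.

The compounds shown leave open what concentration of any of them would reach the half-maximal effect on these cells, and so whether fluoro in place of carbamoyl changes that concentration at all.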